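Working notes on cytotoxicity across one shared core

This account rests on a few compounds, and the source may have more. Where it says the series, first, only, none or still open, it means among the compounds named here.

Compound 1, `COC(=O)c1cc2c(Nc3ccc(OC(F)(F)F)cc3)ncnc2s1`, gives in an ADME assay on BaF3 cells (Mus musculus) for cytotoxicity (a higher number here means that more compound is needed for the effect, a lower number that less compound is needed), only a limit, > 10000 nM.
Compound 2, `NC(=O)c1ccc(Cn2ncc3c(Nc4ccc(OC(F)(F)F)cc4)ncnc32)cc1`, gives in this assay only a limit, > 10000 nM.
Compound 3, `Cc1ccc(NC(=O)c2cccc(C(F)(F)F)c2)cc1C(=O)c1cc2c(Nc3ccc(OC(F)(F)F)cc3)ncnc2s1`, gives in this assay a value of 8900 nM.

Compound 2 therefore sits at the limit of this assay and not at a number; the same holds for compound 1, so that the limit of > 10000 nM in this assay, at which 2 of the 3 values shown sit, describes where two of the three values rest. The value of compound 3 lies within the usual scatter of that limit, so no order among the three can be stated.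

Compound 4, `Cc1nc(C)c(Cn2ncc3c(Nc4ccc(OC(F)(F)F)cc4)ncnc32)s1`, is not yet measured. It differs from compound 2 as follows: 2,4-dimethyl-1,3-thiazol-5-yl in place of 4-carbamoylphenyl on a saturated chain carbon bound to an aromatic nitrogen. Within the data shown here, no measured step runs between two compounds that differ in one place, so nothing here tells the size of such a change. The step from compound 2 to compound 4 in this assay is expected to be none beyond the scatter, as a step that the limit leaves unreadable from compound 2 to compound 4 expresses. Compound 4 is therefore estimated at 12000 nM, with a range from 5000 nM to 30000 nM, and most likely again reported only as a limit.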

Compound 4, half-maximal effective concentration: > 10000 nM
Compound 4 gave a limit, no number; the forecaster's own chance of this, stated with the estimate: 70%; the middle value does not contradict the limit.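

Compound 2 and compound 4 both rest at a limit in this assay and not at a number, so no step can be read between them: the limit of > 10000 nM in this assay, at which 3 of the 4 values shown sit.

The compounds shown leave open whether 2,4-dimethyl-1,3-thiazol-5-yl in place of 4-carbamoylphenyl changes this read-out at all, and in which direction.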